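The compounds below may be only part of what the source reports. "The series", "measured", "known", "first", "only" and "open" are said of these compounds alone.

Measured compounds:
compound 1 `CCCCCCCCCCCCn1nnc(C(C(=O)NC(C)(C)C)c2ccccc2)n1`, in an assay on isolated protein for inhibition of sterol O-acyltransferase 1 (Mus musculus), tested at 0.1 uM (on this read-out higher numbers stand for more inhibition at the one concentration tested (going by the name of the read-out) and lower numbers for less inhibition), compound 1 gives 1%
compound 2 `CCCCCCCCCCCCn1nnc(C(C(=O)Nc2c(OC)cc(OC)cc2OC)c2ccc(OC)cc2)n1`, in this assay compound 2 gives 61%

Compound 2 stands highest of the two numbers shown; compound 1 is the only other measured compound and sits well below it, the gap being beyond the scatter. Going by the values given here, no step between measured compounds that differ in one place is available, so the weight of any single change is not known from the measured pair. Compound 3 `CCCCCCCCCCCCn1nnc(C(Cc2ccccc2)C(=O)Nc2c(OC)cc(OC)cc2OC)n1` differs from compound 2 in one place: benzyl in place of 4-methoxyphenyl on a saturated chain carbon bound to an aromatic carbon and a carbonyl carbon. The remainder of compound 2 is kept. Among the compounds with values here, with no measured step to lean on, a moderate drop in this assay is expected from compound 2 to compound 3, a number 26 percentage points lower from compound 2 to compound 3 (beyond the scatter), the loss of the methoxy-bearing ring being taken as unfavourable but not as severe as the gap down to compound 1. Compound 3 is therefore estimated at 35%, within a range of 10% to 62%.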

Compound 3, a percentage reported as inhibition, at one concentration (the size of the read-out at that concentration, not a potency): 77%
For compound 3 the middle estimate is 42 percentage points below the measured one, outside the stated range (above it).
By their numbers in this assay, from the lowest: compound 1; then compound 2; then compound 3.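

In this assay, going by these compounds alone, the change from 4-methoxyphenyl to benzyl on a saturated chain carbon bound to an aromatic carbon and a carbonyl carbon gives a number 16 percentage points higher from compound 2 to compound 3 (beyond the scatter) and is the first single-place step readable. The entering group counts no hydrogen-bond acceptor where the leaving group counts one, so an acceptor in this group is not required for the inhibition seen with compound 3. No measurement at hand accounts for the direction of this step.

From the compounds shown here alone, the change swaps the methoxy group and adds a chain carbon together, so the share of each in the step stays open; 4-methoxybenzyl at this place would separate them. Also open, going by these compounds, is whether this place accepts a longer chain such as 2-phenylethyl, or an amine or a carboxylic acid.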